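Side-chain change on a benzyl ester lead

The compounds below may be only part of what the source reports. "The series", "measured", "known", "first", "only" and "open" are said of these compounds alone.

Measured compounds:
- compound 1 `CSCC[C@H](NC(=O)CN(c1nc(Cl)nc2[nH]cnc12)C1CC1)C(=O)OCc1ccccc1`: 31.6%
- compound 2 `O=C(CN(c1ncnc2c1ncn2C1CCCCO1)C1CC1)NCC(=O)OCc1ccccc1`: 17.2%
- compound 3 `CSCC[C@H](NC(=O)CN(c1nc(Cl)nc2[nH]cnc12)C1CC1)C(=O)O`: 5.67%

In a functional assay on the whole organism (Tail, strain ICR) with Mus musculus as the target, in the tail flick test, with a stated time of 120 min, at a dose of 25 umol/kg by the oral route (on this read-out higher numbers stand for a stronger effect at the one dose given and lower numbers for a weaker effect), compound 1 gives 31.6%, the highest of the three numbers; compound 2 is lower by more than the scatter, and compound 3 lower still. For the measured compounds named here, the one measured step, a number 25.9 percentage points lower from compound 1 to compound 3 (beyond the scatter), touches the ester end, not the side chain. Compound 4 `NC(=O)C[C@H](NC(=O)CN(c1nc(Cl)nc2[nH]cnc12)C1CC1)C(=O)OCc1ccccc1` differs from compound 1 by carbamoyl in place of (methylsulfanyl)methyl on a saturated chain carbon, two bonds along the chain from an amide-type nitrogen and a carbonyl carbon. Going by the values given here, no measured step bears on this change, so the direction is open; a step within the scatter or a modest fall is expected, because the benzyl ester kept in compound 4 is the one with which compound 1 gives 31.6%. Compound 4 is therefore estimated at 22% (range 5% to 40%), a step of a number 9.6 percentage points lower from compound 1 to compound 4 (within the scatter).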

Compound 4, a percentage reported as activity, at one dose (the size of the read-out at that dose, not a potency): 15.1%
Compound 4: middle estimate off by 6.9 percentage points, on the high side; measured number inside the range.
By their numbers in this assay, from the lowest: compounds 3, 4 and 2 (each within the scatter of the next, the first and the last beyond it); then compound 1.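

In this assay, with the benzyl ester kept, carbamoyl in place of (methylsulfanyl)methyl on this saturated chain carbon gives a number 16.5 percentage points lower from compound 1 to compound 4 (beyond the scatter). The earlier compounds shown here offered a single step, at the ester end, whereas this one shows that the side chain alone also moves the number beyond the scatter. No evidence on the cause of this fall is available. The compounds shown leave open how an amine, a carboxylic acid or a longer chain would read at this position with the benzyl ester kept. They also leave open whether the side-chain change would count the same on the free acid of compound 3.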